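Sulfonylpiperidine series: varying the distal saturated ring substituent

A few compounds are considered here, and "the series" means these few. Any claim that something is new, unique, unknown or untested is made for them only; others in the source may bear on it.

Compound 1 `Cc1cc(C)c(S(=O)(=O)N2CCC(N3CCC(O)CC3)CC2)c(C)c1` stands second highest of three numbers in a functional assay on DLD-1 cells (Homo sapiens) for antiproliferative activity, read by CellTiter-Glo, with a stated time of 72 h (a lower number here means a stronger inhibitor, a higher number a weaker inhibitor), where compound 1 gives 106 nM. Compound 2 `Cc1ccc(C2CCN(S(=O)(=O)c3c(C)cc(C)cc3C)CC2)cc1` gives 2200 nM and compound 3 `Cc1cc(C)c(S(=O)(=O)N2CCC(N3CCCCCC3)CC2)c(C)c1` gives 5.3 nM. Both measured steps start from compound 1: a 21-fold higher number from compound 1 to compound 2 (1.32 log units; beyond the scatter) and a 20-fold lower number from compound 1 to compound 3 (1.30 log units; beyond the scatter), so what sits on that saturated ring carbon moves the number strongly in either direction. Compound 4 `C#CCCC(=O)CC1CCN(C2CCN(S(=O)(=O)c3c(C)cc(C)cc3C)CC2)CC1` differs from compound 1 by ((but-3-yn-1-yl)carbonyl)methyl in place of hydroxy on a saturated ring carbon. Going by the values given here, no measured step alters the hydroxy itself, so none bears directly; the gain in a 20-fold lower number from compound 1 to compound 3 (1.30 log units; beyond the scatter) does show that compound 1 loses nothing when the hydroxy-bearing ring is exchanged, which supports a modest expected improvement. Compound 4 is expected at 35 nM (range 6 nM to 200 nM), an expected step of a 3.0-fold lower number from compound 1 to compound 4 (0.48 log units; beyond the scatter).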

Compound 4, half-maximal inhibitory concentration: 3 nM
Estimate against measurement, compound 4: 12-fold (1.07 log units) above; the measured number lies below the stated range.
By their numbers in this assay, from the lowest: compounds 4 and 3 (each within the scatter of the next); then compound 1; then compound 2.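

Earlier steps exchanged the whole group on the saturated ring carbon, whereas here the ring stays and only the substituent on it changes. In this assay there is a 35-fold lower number from compound 1 to compound 4 (1.55 log units; beyond the scatter) with ((but-3-yn-1-yl)carbonyl)methyl in place of hydroxy, so within this pair the hydroxy is not needed for a low number, and a chain with 0 hydrogen-bond donors is accepted at this carbon. Nothing available accounts for this gain. Still open, from the compounds shown here alone, is which part of the chain carries the step: a plain butyl chain, an amine or a carboxylic acid on the same carbon would help to separate the carbonyl from the triple bond.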